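Fluoro in place of methyl: compound 3 awaits its number

A few compounds are considered here, and "the series" means these few. Any claim that something is new, unique, unknown or untested is made for them only; others in the source may bear on it.

In a functional assay on HCT-116 cells (Homo sapiens) for cytotoxicity, read by MTT assay, with a stated time of 72 h (on this read-out higher numbers stand for weaker inhibition and lower numbers for stronger inhibition), compound 1 (`Cc1ccc(S(=O)(=O)n2cc(COC3=C/C(=N\c4ccccc4)c4ccccc4C3=O)nn2)cc1`) gives 5370 nM and compound 2 (`Cc1ccc(/N=C2\C=C(OCc3cn(S(=O)(=O)c4ccc(C)cc4)nn3)C(=O)c3ccccc32)cc1`) gives 3610 nM. Compound 2 therefore stands level with compound 1, the two values lying within the scatter of each other. Compound 3 (`Cc1ccc(S(=O)(=O)n2cc(COC3=C/C(=N\c4ccc(F)cc4)c4ccccc4C3=O)nn2)cc1`) differs from compound 2 by fluoro in place of methyl on an aromatic carbon, which in words is fluoro in place of methyl on an aromatic carbon, para to a large group. For the measured compounds named here, only one measured step bears on this carbon, a 1.5-fold lower number from compound 1 to compound 2 (0.17 log units; within the scatter), and it is methyl in place of hydrogen on an aromatic carbon. Going by the values given here, no fluoro compound has been measured. Among the compounds with values here, with only that small step as a guide, no change beyond the scatter is expected in this assay. The expected result is a 1.2-fold higher number from compound 2 to compound 3 (0.07 log units; within the scatter). For compound 3 the estimate is 4200 nM, with an expected range of 1900 nM to 9000 nM.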

Compound 3, half-maximal inhibitory concentration: 5750 nM
Estimate against measurement, compound 3: 1.4-fold (0.14 log units) below; the range from low to high includes it.
By their numbers in this assay, from the lowest: compounds 2, 1 and 3 (each within the scatter of the next).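

In this assay, the change from 4-methylphenyl to 4-fluorophenyl gives a small step (a 1.6-fold higher number from compound 2 to compound 3 (0.20 log units; within the scatter)), and fluoro in place of hydrogen on the same carbon gives a smaller one (a 1.1-fold higher number from compound 1 to compound 3 (0.03 log units; within the scatter)). Until now only hydrogen and methyl had been compared on this aromatic carbon; with fluoro as a third group, all three pairs lie within the scatter, so none of these groups sets itself apart from the others in this assay. No measurement is at hand that would account for these values.

What the compounds shown leave open is whether a larger or charged group on this carbon, such as an amine or a carboxylic acid, would move the number beyond the scatter. They also leave open whether methoxy or chloro would behave as fluoro and methyl do here.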